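Phenylethynyl in place of iodoethenyl: cytotoxicity notes

This account rests on a few compounds, and the source may have more. Where it says the series, first, only, none or still open, it means among the compounds named here.

Compound 1 `O=c1[nH]c(=O)n([C@H]2C[C@H](O)[C@@H](CO)O2)cc1/C=C/I` carries the only numerical result in this set: in an ADME assay on L1210/0 cells (Mus musculus) for cytotoxicity, with a stated time of 48 h (a lower number here means a stronger inhibitor, a higher number a weaker inhibitor), compound 1 gives 63900 nM. Compound 2 `Nc1ncnc2c1nnn2[C@@H]1C[C@H](CO)[C@@H](CO)[C@H]1CO` reaches only a limit of this assay, where compound 2 gives > 200000 nM. That is the limit of > 200000 nM in this assay, at which 1 of the 2 values shown sits, the upper edge of what has been seen so far. Compound 3 `O=c1[nH]c(=O)n([C@H]2C[C@H](O)[C@@H](CO)O2)cc1C#Cc1ccccc1` is not yet measured and differs from compound 1 in one place: 2-phenylethynyl in place of 2-iodoethenyl on an aromatic carbon. Going by the values given here, no measured pair differing in a single change is available, so the step size is open; the expected step of a 1.3-fold higher number from compound 1 to compound 3 (0.12 log units; within the scatter) is small, within or just beyond the scatter, if anything toward weaker inhibition. For compound 3 the estimate is 85000 nM, ranging from 15000 nM to 400000 nM.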

Compound 3, half-maximal inhibitory concentration: > 200000 nM
Compound 3: a limit, no number; the forecaster's own chance of this, stated with the estimate: 25%; middle value at least 2.3-fold (0.37 log units) from the limit.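

At this position on the shared core, 2-phenylethynyl in place of 2-iodoethenyl gives an at least 3.1-fold higher number from compound 1 to compound 3 (0.49 log units; beyond the scatter) in this assay, so this change weakens the read-out beyond the scatter. Compound 3 gives > 200000 nM, which is a limit and not a number, so only a lower bound on the step can be read. The series now sits mostly at the upper edge of the assay: the limit of > 200000 nM in this assay, at which 2 of the 3 values shown sit.

Whether the phenyl ring or the triple bond accounts for the step stays open. As far as these compounds go, how a plain ethynyl, a 2-bromoethenyl or an aminomethyl group would read at this position also remains unknown.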